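The compounds below may be only part of what the source reports. "The series", "measured", "known", "first", "only" and "open" are said of these compounds alone.

In a functional assay on THP-1 cells (Homo sapiens) (a higher number here means a larger maximal response, a lower number a smaller maximal response), compound 3 `CCSC[C@@](O)([C@@H](Nc1cccc2nc(C)ccc12)c1ccc(OC)cc1F)C(F)(F)F` gives 85% and stands second highest of the three numbers shown. Compound 1 `CCSC[C@@](O)([C@@H](Nc1cccc2nc(C)ccc12)c1ccc(C)cc1)C(F)(F)F` gives 87%, and compound 2 `CCSC[C@@](O)([C@@H](Nc1cccc2nc(C)ccc12)c1ccc(F)cc1OC)C(F)(F)F` gives 78%; the steps of a number 2 percentage points lower from compound 1 to compound 3 (within the scatter) and a number 7 percentage points higher from compound 2 to compound 3 (within the scatter) both stay within the scatter, so these three numbers cannot be told apart. Compound 4 `CCSC[C@@](O)([C@@H](Nc1cccc2nc(C)ccc12)c1ccc(Cl)c(F)c1OC)C(F)(F)F` differs from compound 3 in one place: 4-chloro-3-fluoro-2-methoxyphenyl in place of 2-fluoro-4-methoxyphenyl on a saturated chain carbon bound to a nitrogen on an aromatic ring and a saturated chain carbon. The measured steps that bear on such a change are a number 9 percentage points lower from compound 1 to compound 2 (within the scatter), a number 2 percentage points lower from compound 1 to compound 3 (within the scatter) and a number 7 percentage points higher from compound 2 to compound 3 (within the scatter), none of which left the scatter. The estimate therefore expects no step beyond the scatter for compound 4 in this assay, namely a number 3 percentage points lower from compound 3 to compound 4 (within the scatter). Compound 4 is expected to give 82%, within a range from 70% to 93%.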

Compound 4, largest response reached (Emax), in percent of the reference or control that the assay uses: 82%
Beside the measured number, compound 4's estimate shows no gap at the digits printed; low and high end bracket the measured number.
By their numbers in this assay, from the lowest: compounds 2, 4, 3 and 1 (each within the scatter of the next).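

In this assay, the saturated chain carbon bound to a nitrogen on an aromatic ring and a saturated chain carbon also carries the 4-chloro-3-fluoro-2-methoxyphenyl group, with its added chlorine, without leaving the scatter: the steps are a number 3 percentage points lower from compound 3 to compound 4 (within the scatter) and a number 4 percentage points higher from compound 2 to compound 4 (within the scatter) and a number 5 percentage points lower from compound 1 to compound 4 (within the scatter) in turn. Across the substituted phenyl groups shown here, the maximal response therefore cannot be told apart. Nothing available explains this result. Going by these compounds, whether any group at this place can move the response beyond the scatter remains open, for instance a pyridine ring or a phenyl ring bearing a carboxylic acid.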